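Swapping the Pyridine Ring for a Lactam in a Ghrelin Agonist

A few compounds are considered here, and "the series" means these few. Any claim that something is new, unique, unknown or untested is made for them only; others in the source may bear on it.

Compounds measured in a functional assay for agonist activity at growth hormone secretagogue receptor type 1 (Homo sapiens), read by FLIPR; a lower number here means a smaller maximal response, a higher number a larger maximal response:
Compound 1, `COc1ccc(N2C[C@@H](C)N[C@@H](C)C2)cc1NS(=O)(=O)c1ccc(-c2cc(Cl)ccc2F)cc1`, gives 1.
Compound 2, `COc1ccc(N2C[C@@H](C)N[C@@H](C)C2)cc1NS(=O)(=O)c1ccc(-c2ccncc2)cc1`, gives 0.7.

Compound 2 stands lowest of these two numbers; its nearest neighbour is compound 1, reached by the step a number 0.30 lower from compound 1 to compound 2 (beyond the scatter). Compound 3, `COc1ccc(N2C[C@@H](C)N[C@@H](C)C2)cc1NS(=O)(=O)c1ccc(N2CCCC2=O)cc1`, has not yet been measured. It differs from compound 2 in one place: 2-oxopyrrolidin-1-yl in place of pyridin-4-yl on an aromatic carbon. For the measured compounds named here, the only measured step, from compound 1 to compound 2, changed the same position but exchanged one aromatic ring for another, and its size is modest. Going by the values given here, no measured step shows what happens when the aromatic ring at this position is replaced by a five-membered non-aromatic ring, so the direction is uncertain. A further modest decrease is expected for compound 3, a number 0.10 lower from compound 2 to compound 3 (within the scatter), with a wide range. The estimate for compound 3 in this assay is therefore 0.6, between 0.3 and 0.9.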

Compound 3, intrinsic activity: the largest response reached, as a fraction of the reference agonist's: 0.8
Estimate against measurement, compound 3: 0.20 below; the range from low to high includes it.
By their numbers in this assay, from the lowest: compounds 2 and 3 (each within the scatter of the next); then compound 1.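

In this assay, the result shows that the aromatic ring at this position can give way to a five-membered non-aromatic ring without a response that can be told apart from that of the pyridin-4-yl compound: the step is a number 0.10 higher from compound 2 to compound 3 (within the scatter). The 5-chloro-2-fluorophenyl group still sets the two smaller-ring compounds apart, since the step with 2-oxopyrrolidin-1-yl is a number 0.20 lower from compound 1 to compound 3 (beyond the scatter), and the pyridin-4-yl compound also stands beyond the scatter from compound 1. Nothing available explains these results at the level of the groups involved.

Going by these compounds, it remains open whether the carbonyl of the 2-oxopyrrolidin-1-yl group matters, which a plain pyrrolidin-1-yl ring would test. An open-chain acetamide or the six-membered piperidin-2-one at the same carbon would show whether the ring itself, or its size, counts.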